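The source may report more compounds than this note shows. Statements on the series, on what has been measured and on what is new or still open speak of the compounds shown alone.

Compound 1, with the structure `CCCN(CCC)c1nc(C(F)(F)F)ccc1CNC(=O)C(C)c1ccc(NS(C)(=O)=O)c(F)c1`, is the reference point of this small series. In a functional assay on CHO-K1 cells for antagonist activity at transient receptor potential cation channel subfamily V member 1 (Homo sapiens), read by FLIPR (on this read-out lower numbers stand for stronger inhibition and higher numbers for weaker inhibition), compound 1 gives 0.2 nM, the lowest number among the three measured compounds, and its steps to both of the others lie beyond the scatter. Compound 2, with the structure `CC(C(=O)NCc1ccc(C(F)(F)F)nc1N1CCC(C(=O)c2ccc(F)cc2)CC1)c1ccc(NS(C)(=O)=O)c(F)c1`, gives 3.9 nM in this assay, and compound 3, with the structure `CC(C(=O)NCc1ccc(C(F)(F)F)nc1N1CCC2(CC1)CC(c1ccccc1)=NO2)c1ccc(NS(C)(=O)=O)c(F)c1`, gives 6.1 nM, so both sit well above compound 1. Compound 4, with the structure `CC(C(=O)NCc1ccc(C(F)(F)F)nc1N1CCN(C2CCCCC2)CC1)c1ccc(NS(C)(=O)=O)c(F)c1`, has not yet been measured. It differs from compound 1 in one place: 4-cyclohexylpiperazin-1-yl in place of dipropylamino on an aromatic carbon. The change sits on the shared core, on an aromatic carbon next to the ring nitrogen and meta to the trifluoromethyl group, where a dipropylamino group is exchanged for a 4-cyclohexylpiperazin-1-yl group carrying two six-membered non-aromatic rings. Since the two measured compounds with values other than compound 1 both lie far above it, the step from compound 1 to compound 4 is expected to be a clear loss, a 15-fold higher number from compound 1 to compound 4 (1.18 log units; beyond the scatter), beyond the scatter. Compound 4 is therefore estimated at 3 nM, within a range from 0.7 nM to 12 nM.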

Compound 4, inhibition constant: 21.6 nM
Beside the measured number, compound 4's estimate is 7.2-fold (0.86 log units) below it; measured number outside the range, above it.
By their numbers in this assay, from the lowest: compound 1; then compounds 2 and 3 (each within the scatter of the next); then compound 4.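

In this assay, within the data shown here, the exchange of dipropylamino for 4-cyclohexylpiperazin-1-yl gives a 110-fold higher number from compound 1 to compound 4 (2.03 log units; beyond the scatter) and is the first single change on the core of compound 1 that can be read directly. It shows that this aromatic carbon, next to the ring nitrogen, does not accept every amine substituent equally: a chain group with no ring gives way to a larger group of two six-membered non-aromatic rings, and the inhibition falls sharply. Nothing measured here gives a reason for this loss.

The compounds shown leave open whether the loss goes with the piperazine ring, its second nitrogen or the cyclohexyl group on it. A plain piperidin-1-yl group or a shorter chain such as diethylamino on the same carbon would help tell these apart.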